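Benzylic substituent variation in a butylamino-pyrimidine TLR8 series

A few compounds are considered here, and "the series" means these few. Any claim that something is new, unique, unknown or untested is made for them only; others in the source may bear on it.

Measured compounds:
compound 1 `CCCCNc1nc(N)nc2c1CN(Cc1cccc(OC)c1Cl)CC2` 0.04 uM
compound 2 `CCCCNc1nc(N)nc2c1CN(Cc1cccc(Cl)c1Cl)CC2` 0.18 uM

Going by the values given here, in an assay on HEK293 cells for agonist activity at Toll-like receptor 8 (Homo sapiens), read by a luciferase reporter, with a stated time of 6 h (a higher number here means that more compound is needed for the effect, a lower number that less compound is needed), compound 2 gives 0.18 uM, the highest of the two numbers so far; its nearest neighbour is compound 1, and the step of a 4.5-fold higher number from compound 1 to compound 2 (0.65 log units; beyond the scatter) is the only one recorded. Compound 3 `CCCCNc1nc(N)nc2c1CN(Cc1ccncc1)CC2` is not yet measured. Its change from compound 2 is pyridin-4-yl in place of 2,3-dichlorophenyl on a saturated chain carbon bound to an amine nitrogen in a ring. Among the compounds with values here, no measured step exchanges a whole aryl group for a heteroaryl, so the chloro-for-methoxy step gives only a rough sense of how much this position moves the number. A modest further rise is expected, a 2.2-fold higher number from compound 2 to compound 3 (0.35 log units; beyond the scatter), with wide uncertainty. The estimate for compound 3 is 0.4 uM, ranging 0.06 uM to 2.5 uM.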

Compound 3, minimum effective concentration: 0.29 uM
For compound 3 the middle estimate is 1.4-fold (0.14 log units) above the measured one; low and high end bracket the measured number.
By their numbers in this assay, from the lowest: compound 1; then compounds 2 and 3 (each within the scatter of the next).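

In this assay, going by these compounds alone, the exchange of the whole aryl group gives a 1.6-fold higher number from compound 2 to compound 3 (0.21 log units; within the scatter), so this is the first step at this position that stays within the scatter. A six-membered ring of carbon only carrying two chlorines and a ring with one hetero atom and one hydrogen-bond acceptor therefore cannot be told apart here. Nothing available explains this result. As far as these compounds go, whether pyridin-3-yl or an unsubstituted phenyl would read the same remains open. So does whether a methoxy group on the pyridin-4-yl ring would change the number.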